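Thiophene-to-furan swap on two ribosyl pyrrolopyrimidine cores

The source may report more compounds than this note shows. Statements on the series, on what has been measured and on what is new or still open speak of the compounds shown alone.

Measured so far:
compound 1 `Cc1ncnc2c1c(-c1ccoc1)cn2[C@@H]1O[C@H](CO)[C@@H](O)[C@H]1O` — 98300 nM
compound 2 `Nc1nc2c(c(-c3cccs3)cn2[C@@H]2O[C@H](CO)[C@@H](O)[C@H]2O)c(=O)[nH]1` — > 100000 nM
compound 3 `Cc1ncnc2c1c(-c1cccs1)cn2[C@@H]1O[C@H](CO)[C@@H](O)[C@H]1O` — > 100000 nM

In an ADME assay on MRC5 cells (Homo sapiens), read by MTT assay, with a stated time of 72 h (on this read-out higher numbers stand for weaker inhibition and lower numbers for stronger inhibition), compound 1 gives 98300 nM. Compound 3 gives only a limit, > 100000 nM. Compound 2 likewise gives only a limit, > 100000 nM. Among the compounds with values here, the step of an at least 1.0-fold lower number from compound 3 to compound 1 (0.00 log units; that floor lies within the scatter) is the one counted change (furan-3-yl in place of thiophen-2-yl on an aromatic carbon). How the core of compound 2 differs from that of compound 3 is not broken down here.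

Compound 4 `Nc1nc2c(c(-c3ccoc3)cn2[C@@H]2O[C@H](CO)[C@@H](O)[C@H]2O)c(=O)[nH]1` is not yet measured in this assay. Its change from compound 2, (furan-3-yl in place of thiophen-2-yl on an aromatic carbon), is the same change as that from compound 3 to compound 1. The step from compound 3 to compound 1 started at the limit of > 100000 nM in this assay, at which 2 of the 3 values shown sit, and ended just inside the measurable range; compound 2 also starts at that limit. The step from compound 2 to compound 4 is therefore expected to be about a number no higher from compound 2 to compound 4 (the limit leaves the size open). Compound 4 is estimated at 100000 nM, between 50000 nM and 200000 nM, with a real chance that only a limit is reported.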

Compound 4, half-maximal inhibitory concentration: 86100 nM
For compound 4 the middle estimate is 1.2-fold (0.06 log units) above the measured one; the range from low to high includes it.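

In this assay, furan-3-yl in place of thiophen-2-yl on the core of compound 2 gives an at least 1.1-fold lower number from compound 2 to compound 4 (0.06 log units; that floor lies within the scatter). Set beside the same change on the other core, the direction is compatible but the sizes cannot be compared: the same change on two cores in this assay, an at least 1.0-fold lower number (0.00 log units; that floor lies within the scatter) from compound 3 to compound 1 and an at least 1.1-fold lower number (0.06 log units; that floor lies within the scatter) from compound 2 to compound 4; the limit leaves it open whether they differ. The result therefore does not show that a measured effect of fixed size carries from one core to the other, as both starting compounds give only a limit: the limit of > 100000 nM in this assay, at which 2 of the 4 values shown sit.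

The compounds shown leave open how this change behaves when the starting compound has a value inside the measurable range. They also leave open whether an amine, a carboxylic acid or a longer chain on that aromatic carbon would give a step beyond the scatter.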